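Swapping cyclohexyl for pyridin-2-yl on an inactive amide

A few compounds are considered here, and "the series" means these few. Any claim that something is new, unique, unknown or untested is made for them only; others in the source may bear on it.

Compound 2 `C#CCn1cc(C(=O)NC(CC(=O)NC2CCCCC2)c2ccccc2)c(=O)c2cc(F)c(Cl)nc21` was tested in a functional assay on HBL-100 cells (Homo sapiens) for cytotoxicity, read by MTT assay, with a stated time of 72 h; on this read-out higher numbers stand for weaker inhibition and lower numbers for stronger inhibition. Compound 2 gives > 10000 nM, which is a limit of the assay rather than a measured number. Compound 3 `C#CCn1cc(C(=O)NC(CC(=O)Nc2ccccn2)c2ccccc2)c(=O)c2cc(F)c(Cl)nc21` differs from compound 2 by pyridin-2-yl in place of cyclohexyl on an amide-type nitrogen. Compound 1 `C#CCn1cc(C(=O)NC(CC(=O)Nc2ccccn2)c2ccccc2)c(=O)c2ccc(Cl)nc21` already carries the pyridin-2-yl amide on a core that differs from the core of compound 2. Compound 1 also gives > 10000 nM, again a limit. With every value sitting at the limit (the limit of > 10000 nM in this assay, at which 2 of the 2 values shown sit), no step beyond the scatter is expected, so the step from compound 2 to compound 3 is estimated as a step that the limit leaves unreadable from compound 2 to compound 3. Compound 3 is expected to give about 15000 nM, within 5000 nM to 50000 nM.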

Compound 3, half-maximal inhibitory concentration: > 10000 nM
Compound 3: a limit, no number; the forecaster's own chance of this, stated with the estimate: 85%; the middle value lies beyond the limit too.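

No step can be read from compound 2 to compound 3 or from compound 1 to compound 3, as every value is a limit: the limit of > 10000 nM in this assay, at which 3 of the 3 values shown sit. The compounds shown leave open whether pyridin-2-yl in place of cyclohexyl, or fluoro in place of hydrogen, changes anything in this assay.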